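This account rests on a few compounds, and the source may have more. Where it says the series, first, only, none or still open, it means among the compounds named here.

Compound 1 `CC1=C(/C=C/C(=O)/C=C/c2ccc(Br)cc2)C(C)(C)CCC1` gives 20100 nM in a functional assay on MCF7 cells (Homo sapiens) for cytotoxicity, read by sulforhodamine B assay, with a stated time of 48 h (on this read-out lower numbers stand for stronger inhibition and higher numbers for weaker inhibition), the highest number among the three measured. Compound 2 `CC1=C(/C=C/C(=O)/C=C/c2ccc(F)cc2)C(C)(C)CCC1` gives 6200 nM, and compound 3 `CC1=C(/C=C/C(=O)/C=C/c2ccc(C#N)cc2)C(C)(C)CCC1` gives 13200 nM. The measured steps, a 3.2-fold lower number from compound 1 to compound 2 (0.51 log units; beyond the scatter), a 1.5-fold lower number from compound 1 to compound 3 (0.18 log units; within the scatter) and a 2.1-fold higher number from compound 2 to compound 3 (0.33 log units; beyond the scatter), each exchange one group for another on the same aromatic carbon; none moves a group to a different carbon. Compound 4 `CC1=C(/C=C/C(=O)/C=C/c2ccccc2Br)C(C)(C)CCC1` differs from compound 1 by 2-bromophenyl in place of 4-bromophenyl on a double-bonded chain carbon bound to a double-bonded chain carbon. Among the measured compounds shown here, no measured step covers such a change, so there is no basis for expecting a shift beyond the scatter in this assay in either direction. Compound 4 is therefore expected at about 20000 nM, with a range from 7000 nM to 55000 nM. The expected step is a 1.0-fold lower number from compound 1 to compound 4 (0.00 log units; within the scatter).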

Compound 4, half-maximal inhibitory concentration: 20700 nM
The estimate for compound 4 lay 1.0-fold (0.01 log units) below the measured number; low and high end bracket the measured number.
By their numbers in this assay, from the lowest: compound 2; then compounds 3, 1 and 4 (each within the scatter of the next).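

In this assay, among the compounds shown here, 2-bromophenyl in place of 4-bromophenyl gives a 1.0-fold higher number from compound 1 to compound 4 (0.01 log units; within the scatter), the first step that changes where a group sits on the aromatic ring rather than which group it is, and it stays within the scatter. Compound 2 remains separated from this new isomer, with a 3.3-fold higher number from compound 2 to compound 4 (0.52 log units; beyond the scatter). No measurement available here accounts for either step. As far as these compounds go, whether fluoro or cyano would tolerate the same change of position remains open, as does the outcome with an amine or a carboxylic acid on the aromatic ring.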